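Thiophene to phenyl on the shared core: compound 4

The source may report more compounds than this note shows. Statements on the series, on what has been measured and on what is new or still open speak of the compounds shown alone.

Three compounds of this series carry measured numbers in a functional assay on T47D cells (Homo sapiens) for cytotoxicity, read by CCK-8 assay and cell counting, with a stated time of 2 days; on this read-out higher numbers stand for weaker inhibition and lower numbers for stronger inhibition. Compound 1 `Oc1ccc(-c2cc(-c3cccc(Cl)c3)nc(-c3ccccn3)c2)cc1` gives 27900 nM; compound 2 `Oc1cccc(-c2cc(-c3ccccc3)nc(-c3cccc(Cl)c3)c2)c1` gives 3700 nM; compound 3 `Oc1ccc(-c2cc(-c3cccc(Cl)c3)nc(-c3cccs3)c2)cc1` gives 5350 nM. Among these, compound 3 stands second highest, with compound 2 the nearest number and within the scatter of it, and compound 1 the furthest, beyond the scatter. Within the data shown here, the one single-point step measured so far, a 5.2-fold lower number from compound 1 to compound 3 (0.72 log units; beyond the scatter), exchanges one small aromatic group for another on the shared core.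

Compound 4 `Oc1ccc(-c2cc(-c3ccccc3)nc(-c3cccc(Cl)c3)c2)cc1` has not yet been measured. It differs from compound 3 in one place: phenyl in place of thiophen-2-yl on an aromatic carbon. Among the measured compounds shown here, no measured step shows this particular exchange. The step from compound 1 to compound 3 bears on it only loosely, as a change of the same ring position on the same core, and it was modest in size. For the measured compounds named here, compound 2, which carries a phenyl group on its core, shows a number close to that of compound 3, though its hydroxyphenyl group is placed differently and no step is drawn between them. A small step is therefore expected, within or near the scatter, and a 1.2-fold lower number from compound 3 to compound 4 (0.08 log units; within the scatter) is the estimated shift. For compound 4 the expected value in this assay is 4500 nM, with a range from 1500 nM to 13000 nM.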

Compound 4, half-maximal inhibitory concentration: 4790 nM
Estimate against measurement, compound 4: 1.1-fold (0.03 log units) below, and the stated range covers the measured number.
By their numbers in this assay, from the lowest: compounds 2, 4 and 3 (each within the scatter of the next); then compound 1.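

Among these compounds, at the position next to the ring nitrogen, phenyl and thiophen-2-yl are not told apart in this assay, with a 1.1-fold lower number from compound 3 to compound 4 (0.05 log units; within the scatter), even though a six-membered ring of carbon only replaces a five-membered ring with a hetero atom; with a 5.8-fold lower number from compound 1 to compound 4 (0.77 log units; beyond the scatter) alongside a 5.2-fold lower number from compound 1 to compound 3 (0.72 log units; beyond the scatter), pyridin-2-yl is the one group of the three at this position that stands apart, and both steps lie beyond the scatter. Among the compounds shown here, the hydroxyl placement on the phenyl core substituent also gives no separation on this pair, with a 1.3-fold higher number from compound 2 to compound 4 (0.11 log units; within the scatter), so 4-hydroxyphenyl and 3-hydroxyphenyl cannot be distinguished here. Nothing available explains why pyridin-2-yl stands apart from the other two groups.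

Still open, from the compounds shown here alone, is whether an amine, a carboxylic acid or a longer alkyl chain at the position next to the ring nitrogen would move the number beyond the scatter in either direction. Also open, going by these compounds, is what a methoxy group in place of the hydroxyl, or a hydrogen in place of the chlorine of the 3-chlorophenyl group, would do on this core.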